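The compounds below may be only part of what the source reports. "The series", "measured", "known", "first", "only" and "open" are said of these compounds alone.

Compound 1, with the structure `CC1=CC[C@H](C(C)(C)NC(=S)N/N=C/c2ccc(F)cc2)CC1`, is a thiosemicarbazone built on a shared core that carries a 4-fluorophenyl group on a carbon with a double bond to nitrogen. In a functional assay on HT-29 cells (Homo sapiens) for inhibition, read by sulforhodamine B assay, with a stated time of 48 h (on this read-out lower numbers stand for stronger inhibition of growth and higher numbers for weaker inhibition of growth), compound 1 gives only a limit, > 100000 nM. Compound 2, with the structure `CC1=CC[C@H](C(C)(C)NC(=S)N/N=C/c2cccc(Cl)c2)CC1`, differs in carrying a 3-chlorophenyl group in that place. In this assay compound 2 gives 53000 nM. The step of an at least 1.8-fold lower number from compound 1 to compound 2 (0.27 log units; that floor lies within the scatter) is therefore only a floor. Compound 2 holds the only number shown. The other value is the limit of > 100000 nM in this assay, at which 1 of the 2 values shown sits.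

Compound 3, with the structure `CC1=CC[C@H](C(C)(C)NC(=S)N/N=C/c2ccc(Cl)cc2)CC1`, is the next step: 4-chlorophenyl in place of 3-chlorophenyl on a carbon with a double bond to nitrogen. Among the compounds with values here, the one measured step that bears on it, the step from compound 1 to compound 2, changed both the halogen and its place on the ring at once and reached no more than a floor within the scatter, so it gives no firm sign of direction for a change of place alone. No step beyond the scatter is therefore expected in this assay, with a modest chance that the value again comes back only as a limit. Compound 3 is expected to give 65000 nM, between 25000 nM and 150000 nM. That estimate means a step of a 1.2-fold higher number from compound 2 to compound 3 (0.09 log units; within the scatter), expected to lie within the scatter.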

Compound 3, concentration for total growth inhibition: 70500 nM
Compound 3: middle estimate off by 1.1-fold (0.04 log units), on the low side, within the range that was stated.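

Swapping 3-chlorophenyl for 4-chlorophenyl keeps the same atoms and joins them differently, and it gives a 1.3-fold higher number from compound 2 to compound 3 (0.12 log units; within the scatter) in this assay. Within the data shown here, this is the first pair in which only the place of the chlorine changes, since the earlier step from the 4-fluorophenyl to the 3-chlorophenyl compound altered both the halogen and its place, and here moving the chlorine produces no difference that can be told from the scatter. Compound 3 also isolates chloro in place of fluoro on an aromatic carbon, but that step, an at least 1.4-fold lower number from compound 1 to compound 3 (0.15 log units; that floor lies within the scatter), can be read only as a floor that does not rise beyond the scatter, because compound 1 gives a limit rather than a number: the limit of > 100000 nM in this assay, at which 1 of the 3 values shown sits.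

The three compounds carry only halogens on the aromatic ring, so they leave open whether a methoxy group, an amine or a carboxylic acid there would give a step beyond the scatter. They also leave open how growth inhibition in these cells would respond to any change on the shared core itself, such as a longer chain in place of its methyl groups.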